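The source may report more compounds than this note shows. Statements on the series, on what has been measured and on what is new or still open speak of the compounds shown alone.

Compound 1 `O=C(O)c1ccc(Cn2c(C(=O)O)cc3cc(S(=O)(=O)N(Cc4ccccc4)Cc4ccccc4)ccc32)cc1` stands highest of the two compounds measured in an assay on cells (Oocyte) for inhibition of pannexin-1 (Mus musculus), read by voltage clamp, tested at 50 uM, in the presence of a further agent that is not named here; on this read-out lower numbers stand for less inhibition and higher numbers for more inhibition at the one concentration tested (going by the name of the read-out): compound 1 gives 100%, while compound 2 `O=C(O)c1cc2cc([N+](=O)[O-])ccc2n1CCCc1ccccc1` gives 65.5%, a gap beyond the scatter. Compound 3 `O=C(O)c1cc2cc(S(=O)(=O)N(Cc3ccccc3)Cc3ccccc3)ccc2n1Cc1ccccc1` has not yet been tested. It differs from compound 1 in one place (hydrogen in place of carboxy on an aromatic carbon); cut one bond further out, the change reads 4-carboxybenzyl to benzyl. Among the compounds with values here, no measured pair shows this change. Since compound 1 already gives 100%, a modest fall is expected a number 15 percentage points lower from compound 1 to compound 3 (beyond the scatter). Compound 3 is therefore estimated at 85%, within a range from 60% to 100%.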

Compound 3, a percentage reported as inhibition, at one concentration (the size of the read-out at that concentration, not a potency): 41%
Estimate against measurement, compound 3: 44 percentage points above; measured number outside the range, below it.
By their numbers in this assay, from the lowest: compound 3; then compound 2; then compound 1.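

Hydrogen in place of carboxy on the aromatic carbon of the 4-carboxybenzyl group gives, in this assay, a number 59 percentage points lower from compound 1 to compound 3 (beyond the scatter). This first pair differing in one place shows that the read-out at the one concentration tested depends heavily on this single carboxy group, with the rest of the structure unchanged. Nothing available explains why the loss is so large. The compounds shown leave open whether a methyl ester, a primary amide or a hydroxy group at this place would keep the read-out near that of compound 1 or let it fall towards that of compound 3. They also leave open how a longer chain carrying the carboxy group would read.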